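Methyl for chloro: an estimate for compound 3

This account rests on a few compounds, and the source may have more. Where it says the series, first, only, none or still open, it means among the compounds named here.

Measured so far:
compound 1 `Cc1cc(C)c2nc(C3(c4ccc(Cl)cc4)CC3)c(O)c(C(=O)O)c2c1` — 47%
compound 2 `CC(C)C(c1ccc(Cl)cc1)c1nc2c(C(F)(F)F)cccc2c(C(=O)O)c1O` — <= 10%

Among the compounds with values here, in an assay on isolated protein for inhibition of P-selectin glycoprotein ligand 1 (Homo sapiens), read by surface plasmon resonance, tested at 250 uM (a lower number here means less inhibition, a higher number more inhibition at the concentration tested (going by the name of the read-out)), compound 1 gives 47%, the only number. For compound 2 the read-out is a limit rather than a number, <= 10%, which is the limit of <= 10% in this assay, at which 1 of the 2 values shown sits. Within the data shown here, compound 1 therefore stands as the sole numeric anchor, and no pair of measured compounds differs in one place, so no measured step is available to size a single change.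

Compound 3 (`Cc1ccc(C2(c3nc4c(C)cc(C)cc4c(C(=O)O)c3O)CC2)cc1`) differs from compound 1 by methyl in place of chloro on an aromatic carbon. With nothing measured to guide it, the step is expected to be small, within the usual scatter or a slight decrease: the expected step from compound 1 to compound 3 is a number 7 percentage points lower from compound 1 to compound 3 (within the scatter). Compound 3 is accordingly estimated to give 40% in this assay, with an expected range from 20% to 60%.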

Compound 3, a percentage reported as inhibition, at one concentration (the size of the read-out at that concentration, not a potency): 11%
Beside the measured number, compound 3's estimate is 29 percentage points above it; measured number below the stated range.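

In this assay, the change from 4-chlorophenyl to 4-methylphenyl on the shared core is not a neutral exchange: the step reads a number 36 percentage points lower from compound 1 to compound 3 (beyond the scatter). Both groups have the same heavy-atom count, and neither brings a hydrogen-bond donor, a hydrogen-bond acceptor or a net charge, so these counts do not separate them, yet the read-out does. Compound 2 is a limit and not a number, and no step ties it to this pair: the limit of <= 10% in this assay, at which 1 of the 3 values shown sits.

A single exchange leaves open whether the read-out depends on chloro itself or would also stay level with other groups at this place, such as fluoro, methoxy or an amine. Also open, as far as these compounds go, is whether the same exchange would read alike on the core of compound 2.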